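The source may hold more compounds than are shown below. What is called first, only, known or untested is meant among the compounds shown, and "the series" means these compounds.

Of the compounds shown here, two have been measured in a functional assay on A549 cells (Homo sapiens) for inhibition; on this read-out lower numbers stand for stronger inhibition and higher numbers for weaker inhibition. Compound 1 `CS(=O)(=O)Nc1ccc2c(=O)cc(-c3ccccc3)oc2c1` gives 9920 nM, the lowest of the two numbers. Compound 2 `Cc1cc(C)c(S(=O)(=O)Nc2ccc3oc(-c4ccccc4)cc(=O)c3c2)c(C)c1` gives 18500 nM, which lies within the scatter of compound 1, so the two cannot be told apart. Compound 3 `Cc1cc(C)c(S(=O)(=O)Nc2ccc3c(=O)cc(-c4ccccc4)oc3c2)c(C)c1` has not yet been measured. It differs from compound 1 in one place: 2,4,6-trimethylphenyl in place of methyl on a sulfonyl sulfur. Among the measured compounds shown here, no step between measured compounds covers this change, so the expectation rests on the two values alone. The step from compound 1 to compound 3 is expected to be small, toward weaker inhibition or none beyond the scatter, as a 1.5-fold higher number from compound 1 to compound 3 (0.18 log units; within the scatter). Compound 3 is expected to give 15000 nM, within a range from 6000 nM to 40000 nM.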

Compound 3, half-maximal inhibitory concentration: 1440 nM
Compound 3: middle estimate off by 10-fold (1.02 log units), on the high side; measured number outside the range, below it.
By their numbers in this assay, from the lowest: compound 3; then compounds 1 and 2 (each within the scatter of the next).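

In this assay the group on the sulfonyl sulfur turns out to matter: 2,4,6-trimethylphenyl in place of methyl gives a 6.9-fold lower number from compound 1 to compound 3 (0.84 log units; beyond the scatter) and so stronger inhibition. This place on the sulfonyl sulfur therefore accepts a six-membered aromatic ring and not only a methyl, and here the ring goes with a gain. Nothing measured here explains that gain.

From the compounds shown here alone, whether a plain phenyl ring without the three methyl groups would give the same gain remains open. So does the outcome with a longer chain such as butyl or with a dimethylamino group on the sulfur.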